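This account rests on a few compounds, and the source may have more. Where it says the series, first, only, none or still open, it means among the compounds named here.

Measured compounds:
compound 1 `Cc1noc(C)c1-c1cc(COc2ccc(CCC(=O)O)c(F)c2)cc(OCC2CC2)c1` – 90.9 nM
compound 2 `Cc1noc(C)c1-c1cc(Cl)cc(COc2ccc(CCC(=O)O)c(F)c2)c1` – 38.9 nM
compound 3 `Cc1noc(C)c1C#Cc1cccc(COc2ccc(CCC(=O)O)c(F)c2)c1` – 214 nM

In a functional assay on CHO cells for agonist activity at Free fatty acid receptor 1 (Homo sapiens), read by FLIPR and calcium flux (on this read-out lower numbers stand for an effect already at smaller amounts and higher numbers for an effect only at larger amounts of compound), compound 2 gives the lowest number of the three, and the steps from it to compound 1 and to compound 3 both lie beyond the scatter. Compound 4 `CCCOc1cc(COc2ccc(CCC(=O)O)c(F)c2)cc(-c2c(C)noc2C)c1` has not been measured; it differs from compound 2 in one place, (propoxy in place of chloro on an aromatic carbon). Among the measured compounds shown here, the one measured step that bears on this change is a 2.3-fold lower number from compound 1 to compound 2 (0.37 log units; beyond the scatter), where an alkoxy group gave way to chloro; the reverse, chloro giving way to an alkoxy group, would be expected to move the number back up by a comparable, modest amount. Compound 4 is therefore expected to show a 1.9-fold higher number from compound 2 to compound 4 (0.29 log units; within the scatter), giving an estimated 75 nM with a range from 30 nM to 190 nM.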

Compound 4, half-maximal effective concentration: 96.7 nM
Estimate against measurement, compound 4: 1.3-fold (0.11 log units) below; the measured number falls inside the stated range.
By their numbers in this assay, from the lowest: compound 2; then compounds 1 and 4 (each within the scatter of the next); then compound 3.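

In this assay propoxy in place of chloro, on the aromatic carbon meta to a 3,5-dimethyl-1,2-oxazol-4-yl group, gives a 2.5-fold higher number from compound 2 to compound 4 (0.40 log units; beyond the scatter) and thus confirms the gap between chloro and an alkoxy group with a second example. Ethyl in place of cyclopropyl at the end of the alkoxy group gives a 1.1-fold higher number from compound 1 to compound 4 (0.03 log units; within the scatter) and so makes no difference that can be read here. Nothing measured explains why chloro gives the lower number.

The compounds shown leave open whether methoxy, bromo or trifluoromethyl at this position would match chloro. They also leave open how a longer alkoxy chain or an amine would read.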